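This account rests on a few compounds, and the source may have more. Where it says the series, first, only, none or still open, it means among the compounds named here.

Compound 1 `O=c1cc(-c2ccccc2)oc2ccc(OC/C(=N/O)c3ccccc3)cc12` gives 700000 nM in a functional assay on SK-HEP1 cells (Homo sapiens) for antiproliferative activity; on this read-out higher numbers stand for weaker inhibition of growth and lower numbers for stronger inhibition of growth. Compound 2 `O=c1cc(-c2ccccc2)oc2ccc(OC/C(=N/O)c3ccc(F)cc3)cc12` differs from it by fluoro in place of hydrogen on an aromatic carbon and gives 2800000 nM in this assay, so that a 4.0-fold higher number from compound 1 to compound 2 (0.60 log units; beyond the scatter). Compound 3 `O=c1cc(-c2ccccc2)oc2cc(OC/C(=N/O)c3ccccc3)ccc12` has the same atoms as compound 1 joined differently; how the two cores differ is not broken down here, and compound 3 gives 2000000 nM in this assay, while its value and that of compound 2 lie within the scatter of each other. Compound 4 `O=c1cc(-c2ccccc2)oc2cc(OC/C(=N/O)c3ccc(F)cc3)ccc12` is not yet measured; it differs from compound 3 by fluoro in place of hydrogen on an aromatic carbon, the same change as that from compound 1 to compound 2. For compound 4 a step of a 3.0-fold higher number from compound 3 to compound 4 (0.48 log units; beyond the scatter) is expected, resting on the measured step of a 4.0-fold higher number from compound 1 to compound 2 (0.60 log units; beyond the scatter). The estimate for compound 4 in this assay is 6000000 nM, between 2000000 nM and 15000000 nM.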

Compound 4, concentration for 50% growth inhibition: 2300000 nM
The estimate for compound 4 lay 2.6-fold (0.42 log units) above the measured number, and the stated range covers the measured number.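

In this assay, the change from phenyl to 4-fluorophenyl on the second core gives a 1.2-fold higher number from compound 3 to compound 4 (0.06 log units; within the scatter). Set beside the earlier step, the size of this change does not carry over from the core of compound 1 to the core of compound 3: the same change on two cores in this assay, a 4.0-fold higher number (0.60 log units; beyond the scatter) from compound 1 to compound 2 and a 1.2-fold higher number (0.06 log units; within the scatter) from compound 3 to compound 4, 3.5-fold (0.54 log units) apart, beyond the scatter of two such steps. For the compounds shown here, this rests on a single pair on each core, so it shows only that the step cannot be assumed to transfer between these two cores; it does not show why the two steps differ, or how any other change would transfer.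

The compounds shown leave open whether chloro, methoxy or an amine in place of the fluoro would give matching steps on the two cores.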